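A few compounds are considered here, and "the series" means these few. Any claim that something is new, unique, unknown or untested is made for them only; others in the source may bear on it.

Measured compounds in the series:

compound 1, `CC(C)(C)OC(=O)Nc1ncc(C(Oc2ccc(Br)cc2)c2ccc(Cl)cc2)s1`, with > 50000 nM
compound 2, `COc1ccc(Br)c(COC(c2ccccc2)c2cnc(NC(=O)c3cccs3)s2)c1`, with "not toxic" (no number reported)
compound 3, `CCOC(=O)CCCNc1ncc(C(Oc2ccc3cc(Br)ccc3c2)c2ccc(Cl)cc2)s1`, with "not toxic" (no number reported)

The read-out throughout is an ADME assay on HepG2 2.2.15 cells (Homo sapiens) for cytotoxicity; a lower number here means that less compound is tolerated, a higher number that more compound is tolerated. For compound 1 the value is a limit of the assay, not a number; this is the limit of > 50000 nM in this assay, at which 1 of the 3 values shown sits. Compound 2 has no number at all, only the entry "not toxic" (no number reported). Compound 3 likewise carries no single number in this assay, its entry being "not toxic" (no number reported). Of the other two entries, that of compound 1 is a limit and that of compound 2 is an entry without a number. Nothing in the three measured compounds separates them from one another on the half-maximal cytotoxic concentration, so no ordering can be drawn.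

The next compound, compound 4, is `O=C(Nc1ncc(C(Oc2ccc3cc(Br)ccc3c2)c2ccc(Cl)cc2)s1)c1ccccc1`. It differs from compound 3 in one place: benzoyl in place of 3-(ethoxycarbonyl)propyl on a nitrogen on an aromatic ring. Among the compounds with values here, no measured step between any two of the shared-core compounds is available, so no size of effect on this assay can be read from the series. With all three measured entries sitting at or beyond the tolerated range, the expectation for compound 4 in this assay is no change beyond the scatter, most likely again a limit rather than a number.

The half-maximal cytotoxic concentration of compound 4 is estimated at 50000 nM, within the range 20000 nM to 100000 nM.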

Compound 4, half-maximal cytotoxic concentration: "not toxic" (no number reported)
Compound 4: no number reported, so the estimate cannot be set against anything.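

No step can be read between compound 3 and compound 4 in this assay: neither entry is a number. The compounds shown leave open the concentration at which any of them becomes cytotoxic in this assay, and so whether benzoyl and 3-(ethoxycarbonyl)propyl on a nitrogen on an aromatic ring differ at all.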